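A few compounds are considered here, and "the series" means these few. Any claim that something is new, unique, unknown or untested is made for them only; others in the source may bear on it.

Measured in a physicochemical assay for solubility, at pH 7; a higher number here means a more soluble compound, a lower number a less soluble compound:
- compound 1 `CN1CCC(C(=O)N2Cc3c(NC(=O)c4ccsc4)n[nH]c3C2(C)C)CC1`: > 225000 nM (a limit)
- compound 2 `CN1CCN(C(=O)N2Cc3c(NC(=O)c4ccc(F)cc4)n[nH]c3C2(C)C)CC1`: > 225000 nM (a limit)
- compound 3 `CC(C)(C)C(=O)N1Cc2c(NC(=O)c3ccncc3)n[nH]c2C1(C)C`: 205000 nM

In this assay compound 1 reads > 225000 nM, which is a limit and not a number. It therefore stands with compound 2 at the top of the range: the limit of > 225000 nM in this assay, at which 2 of the 3 values shown sit. Compound 3 gives the only numeric result, 205000 nM.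

Compound 4 `CN1CCC(C(=O)N2Cc3c(NC(=O)c4cccc(F)c4)n[nH]c3C2(C)C)CC1` is not yet measured. Its change from compound 1 is 3-fluorophenyl in place of thiophen-3-yl on a carbonyl carbon. Going by the values given here, no two measured compounds differ in one place only, so no measured step guides the expectation. Compound 2, which also carries a fluorophenyl on that carbonyl, gives > 225000 nM, again a limit. The expected step, an at least 1.0-fold lower number from compound 1 to compound 4 (0.01 log units; that floor lies within the scatter), is estimated to lie within the scatter, with no direction favoured. For compound 4 the estimated value in this assay is 215000 nM, with an expected range of 130000 nM to 240000 nM.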

Compound 4, solubility: > 225000 nM
Compound 4 gave a limit, no number (the forecaster's own chance of this, stated with the estimate: 60%); middle value at least 1.0-fold (0.01 log units) from the limit.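

In this assay compound 4 gives > 225000 nM, a limit and not a number. Going by these compounds alone, compound 1 is also a limit, and no step from compound 1 to compound 4 can be read. The compounds shown leave open whether 3-fluorophenyl and thiophen-3-yl on that carbonyl differ at all in this assay.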